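The source may report more compounds than this note shows. Statements on the series, on what has been measured and on what is new or still open speak of the compounds shown alone.

Compound 1, `C#CCCCOc1ccc2cc(C(=O)O)c(=O)oc2c1`: > 10000 nM in an assay on cells for inhibition of Amine oxidase [flavin-containing] B (Homo sapiens), read by Amplex Red, with stated times of 30 min and 45 min; a higher number here means a weaker inhibitor, a lower number a stronger inhibitor
Compound 2, `C#CCCCOc1ccc2cc(NC(C)=O)c(=O)oc2c1`: 43.6 nM in this assay

For compound 1 the value in this assay is only a limit, (the limit of > 10000 nM in this assay, at which 1 of the 2 values shown sits), not a number. Compound 2 gives the only actual number shown in this assay, 43.6 nM. For the measured compounds named here, the one other value shown, that of compound 1, is a limit. Compound 2 therefore stands alone as a measured point. Going by the values given here, the single measured step, an at least 220-fold lower number from compound 1 to compound 2 (2.36 log units; beyond the scatter), concerns acetamido in place of carboxy on an aromatic carbon and leaves the chain untouched. Compound 3, `C#CCCCCOc1ccc2cc(NC(C)=O)c(=O)oc2c1`, differs from compound 2 by propargyl in place of ethynyl on a saturated chain carbon, three bonds along the chain from an oxygen on an aromatic ring. Among the compounds with values here, no measured step bears on a lengthening of this chain, and the one step that exists altered a different part of the shared core. With nothing pointing either way, the expected step of a 1.1-fold higher number from compound 2 to compound 3 (0.06 log units; within the scatter) is none beyond the scatter. Compound 3 is therefore estimated at 50 nM in this assay, with a range from 15 nM to 170 nM.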

Compound 3, half-maximal inhibitory concentration: 41.7 nM
The estimate for compound 3 lay 1.2-fold (0.08 log units) above the measured number; the range from low to high includes it.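

In this assay, for the compounds shown here, the hex-5-yn-1-yl chain of compound 3 and the pent-4-yn-1-yl chain of compound 2 give the first measured step at this position of the chain (a 1.0-fold lower number from compound 2 to compound 3 (0.02 log units; within the scatter)). The two compounds cannot be told apart, so with the acetamido group in place, the extra carbon carries no measurable cost or gain in this pair. Nothing in the data shown bears on why this chain difference leaves the two numbers within the scatter.

On these data alone, whether this holds for the shorter but-3-yn-1-yl or propargyl chains, for a longer chain than hex-5-yn-1-yl, or for a saturated hexyl chain remains open. So does whether the same chain difference would read alike with an amine or a longer amide in place of the acetamido group.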